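The source may report more compounds than this note shows. Statements on the series, on what has been measured and on what is new or still open speak of the compounds shown alone.

Measured compounds in a functional assay on SW1573 cells (Homo sapiens) for inhibition, read by sulforhodamine B assay, with a stated time of 48 h; a lower number here means a stronger inhibitor of growth, a higher number a weaker inhibitor of growth:
- compound 1, `COC(=O)[C@@]1(C)CC[C@@H]2C3=C1CC[C@@H](C)[C@]3(C)C[C@@H]1c3ccccc3N[C@H]21`: compound 1 gives 30000 nM
- compound 2, `COC(=O)[C@@]1(C)CC[C@@H]2C3=C1CC[C@@H](C)[C@]3(C)C[C@@H]1c3cc(C)ccc3N[C@H]21`: compound 2 gives 23000 nM
- compound 3, `COC(=O)[C@@]1(C)CC[C@@H]2C3=C1CC[C@@H](C)[C@]3(C)Cc1c2[nH]c2ccccc12`: compound 3 gives 8300 nM

Compound 1 and compound 2 share one core; compound 3 carries a different core, and the difference between the two cores is not broken down here. Compound 3 stands lowest of the three numbers, and both the step from compound 2 and the step from compound 1 to it lie beyond the scatter.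

Within the first core, the only change is methyl in place of hydrogen on an aromatic carbon, and it made a step of a 1.3-fold lower number from compound 1 to compound 2 (0.12 log units; within the scatter). The same group is now placed on the core of compound 3 to give compound 4, `COC(=O)[C@@]1(C)CC[C@@H]2C3=C1CC[C@@H](C)[C@]3(C)Cc1c2[nH]c2c(C)cccc12`, not yet measured, by the change (methyl in place of hydrogen on an aromatic carbon). This is the same kind of change, not the same: in compound 2 the methyl sits meta to a fused ring and para to a fused ring, whereas in compound 4 it sits ortho to a fused ring and meta to a fused ring.

With a single precedent, the expectation for compound 4 rests on that precedent alone: because the step of a 1.3-fold lower number from compound 1 to compound 2 (0.12 log units; within the scatter) stayed within the scatter, the step from compound 3 to compound 4 is expected to be small as well, estimated as a 1.2-fold lower number from compound 3 to compound 4 (0.07 log units; within the scatter). Compound 4 is therefore estimated at 7000 nM in this assay, with the range 3000 nM to 17000 nM taken as the expected spread.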

Compound 4, concentration for 50% growth inhibition: 16000 nM
The estimate for compound 4 lay 2.3-fold (0.36 log units) below the measured number; the range from low to high includes it.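

In this assay, methyl in place of hydrogen on an aromatic carbon gives a 1.9-fold higher number from compound 3 to compound 4 (0.29 log units; within the scatter), so on the core of compound 3 this change again stays inside the usual scatter. Set beside the step on the core of compound 1, the new step cannot be told apart from it: the same change on two cores in this assay, a 1.3-fold lower number (0.12 log units; within the scatter) from compound 1 to compound 2 and a 1.9-fold higher number (0.29 log units; within the scatter) from compound 3 to compound 4, 2.5-fold (0.40 log units) apart, within the scatter of two such steps. Within the data shown here, this shows that in these two pairs the methyl carries from one core to the other without a step that stands out from the scatter, but it does not show that the change is without effect in general, since there is only one pair per core, the direction of neither step can be read, and the placement is not the same on the two cores, with the methyl in compound 4 ortho to a fused ring and meta to a fused ring.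

The compounds shown leave open whether a group other than methyl on this aromatic ring, such as a longer chain like ethyl, an amine or a carboxylic acid, would give a step beyond the scatter. Also open, from the compounds shown here alone, is whether methyl on the other aromatic carbons of either core would do so.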